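The source may hold more compounds than are shown below. What is called first, only, known or untested is meant among the compounds shown, and "the series" means these compounds.

Compound 1 `CC(=O)Nc1ncc(SCc2ncc(C(C)(C)C)o2)s1`: 50 nM
Compound 2 `CC(C)(C)c1cnc(CSc2cnc(NC(=O)OCc3ccccc3)s2)o1`: 1040 nM

In a functional assay on A2780 cells (Homo sapiens) for cytotoxicity (a lower number here means a stronger inhibitor, a higher number a weaker inhibitor), compound 2 has the higher of the two numbers. Compound 3 `CC(C)(C)c1cnc(CSc2cnc(NC(=O)Nc3ccc(F)cc3)s2)o1` carries (4-fluorophenyl)amino in place of benzyloxy on a carbonyl carbon. Among the compounds with values here, the only measured step at this carbonyl carbon is large, a 21-fold higher number from compound 1 to compound 2 (1.32 log units; beyond the scatter), but it replaces methyl and does not test this exchange. Only a modest fall in the number is therefore expected, with low confidence in its direction, and the estimated change is a 1.7-fold lower number from compound 2 to compound 3 (0.24 log units; within the scatter). For compound 3 the expected value is 600 nM, with an estimated range of 150 nM to 2500 nM.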

Compound 3, half-maximal inhibitory concentration: 900 nM
Compound 3: middle estimate off by 1.5-fold (0.18 log units), on the low side, within the range that was stated.
By their numbers in this assay, from the lowest: compound 1; then compounds 3 and 2 (each within the scatter of the next).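

In this assay, the step of a 1.2-fold lower number from compound 2 to compound 3 (0.06 log units; within the scatter) means that benzyloxy and (4-fluorophenyl)amino cannot be told apart on this carbonyl carbon. Both stand well away from methyl, with an 18-fold higher number from compound 1 to compound 3 (1.26 log units; beyond the scatter) matching the earlier 21-fold higher number from compound 1 to compound 2 (1.32 log units; beyond the scatter), so the large gap is now seen with two different groups, each carrying a six-membered aromatic ring. No supporting measurement accounts for this gap.

The compounds shown leave open where between methyl and these two groups the gap opens. Ethyl, dimethylamino or unsubstituted phenyl on this carbonyl carbon would each narrow that question.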